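A few compounds are considered here, and "the series" means these few. Any claim that something is new, unique, unknown or untested is made for them only; others in the source may bear on it.

Compound 3 `Nc1nc(-c2cocn2)nc2sc(CN3CC=CC3)cc12` stands at the top of the three numbers available in an assay on CHO-K1 cells for antagonist activity at adenosine receptor A1 (Homo sapiens), read by a beta-galactosidase reporter, with stated times of 15 min and 6 h; a lower number here means a stronger inhibitor, a higher number a weaker inhibitor: compound 3 gives 3900 nM, while compound 1 `Nc1nc(-c2ccco2)nc2sc(CN3CC=CCC3)cc12` gives 150 nM and compound 2 `Nc1nc(-c2ccc(Cl)o2)nc2sc(CN3CC=CCC3)cc12` gives 190 nM. Among the measured compounds shown here, the only step measured between neighbours, a 1.3-fold higher number from compound 1 to compound 2 (0.10 log units; within the scatter), concerns the furan substituent and does not touch the change now in question.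

Compound 4 `Nc1nc(-c2cocn2)nc2sc(CN3CC=CCC3)cc12` differs from compound 3 by a group of 6 heavy atoms (5 carbon, 1 nitrogen; one six-membered non-aromatic ring with 1 hetero atom) in place of a group of 5 heavy atoms (4 carbon, 1 nitrogen; one five-membered non-aromatic ring with 1 hetero atom), on a saturated chain carbon bound to an aromatic carbon. For the measured compounds named here, compounds 1 and 2 carry the six-membered ring that enters here, but they also carry a different aromatic substituent on the shared core, so their values show only that the six-membered ring is compatible with a much lower number; they do not isolate the ring change itself. Going by the values given here, no measured step therefore bears directly on the step from compound 3 to compound 4, and the direction rests on the comparison between compound 3 and the pair of compounds 1 and 2.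

On that basis, compound 4 is expected to move toward a lower number than compound 3, a step estimated as a 2.6-fold lower number from compound 3 to compound 4 (0.41 log units; beyond the scatter), though with wide uncertainty. Compound 4 is estimated at 1500 nM, with a range from 400 nM to 6000 nM in this assay.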

Compound 4, inhibition constant: 2960 nM
Beside the measured number, compound 4's estimate is 2.0-fold (0.30 log units) below it, within the range that was stated.
By their numbers in this assay, from the lowest: compounds 1 and 2 (each within the scatter of the next); then compounds 4 and 3 (each within the scatter of the next).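

In this assay, with 1,3-oxazol-4-yl held in place, the six-membered ring in place of the five-membered ring on the saturated chain carbon gives a 1.3-fold lower number from compound 3 to compound 4 (0.12 log units; within the scatter), so this pair does not separate the two rings. Compound 4 also supplies the comparison that the earlier compounds lacked: with the six-membered ring held in place, 1,3-oxazol-4-yl in place of furan-2-yl gives a 20-fold higher number from compound 1 to compound 4 (1.30 log units; beyond the scatter), and 1,3-oxazol-4-yl in place of 5-chlorofuran-2-yl gives a 16-fold higher number from compound 2 to compound 4 (1.19 log units; beyond the scatter), so among these four compounds the large differences follow the aromatic substituent and not the ring on the chain carbon. Nothing available accounts for these differences.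

As far as these compounds go, it remains open whether the ring change would read the same way with furan-2-yl or 5-chlorofuran-2-yl on the shared core. The compounds shown also leave open how a piperidine, a morpholine or an open-chain diethylamine on the same chain carbon would compare, and how a thiophene or a phenyl group would stand among the aromatic substituents.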